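Swapping the Ethoxy of Compound 2 for Isopropyl

The source may hold more compounds than are shown below. What is called first, only, known or untested is meant among the compounds shown, and "the series" means these compounds.

Measured so far:
Compound 1 `O=C(/C=C/c1ccc(O)c(O)c1)c1cc(O)ccc1O`: 64 nM
Compound 2 `CCOc1ccc(O)c(C(=O)/C=C/c2ccc(O)c(O)c2)c1`: 5.3 nM

In an assay on RBL-1 cells for inhibition of Polyunsaturated fatty acid 5-lipoxygenase (Rattus norvegicus) (on this read-out higher numbers stand for weaker inhibition and lower numbers for stronger inhibition), compound 2 stands lowest of the two numbers; its nearest neighbour, compound 1, gives 64 nM. Within the data shown here, the one measured step, a 12-fold lower number from compound 1 to compound 2 (1.08 log units; beyond the scatter), added ethyl to an oxygen. Compound 3 `CC(C)c1ccc(O)c(C(=O)/C=C/c2ccc(O)c(O)c2)c1` carries isopropyl in place of ethoxy on an aromatic carbon. Among the measured compounds shown here, no measured step swaps ethoxy for a carbon group of the same size, so that step cannot be read across. The expectation for compound 3 in this assay is therefore no step beyond the scatter from compound 2, a 1.1-fold higher number from compound 2 to compound 3 (0.05 log units; within the scatter). Compound 3 is estimated at 6 nM, between 2 nM and 20 nM.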

Compound 3, half-maximal inhibitory concentration: 4 nM
Estimate against measurement, compound 3: 1.5-fold (0.18 log units) above; the measured number falls inside the stated range.
By their numbers in this assay, from the lowest: compounds 3 and 2 (each within the scatter of the next); then compound 1.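

Trading ethoxy for isopropyl on this aromatic carbon gives a 1.3-fold lower number from compound 2 to compound 3 (0.12 log units; within the scatter), so in this assay the oxygen of the ethoxy is not required for the low number. Isopropyl in place of hydroxy gives a 16-fold lower number from compound 1 to compound 3 (1.20 log units; beyond the scatter), which shows that a carbon group with no hydrogen-bond acceptor matches the large step that ethoxy gave. Nothing available explains why these two groups behave alike. Going by these compounds, whether a methyl, a longer chain such as butyl, or an amine on this carbon would keep the number this low remains open.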